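Trimming the Indazole to a Pyrazole

The source may hold more compounds than are shown below. What is called first, only, known or untested is meant among the compounds shown, and "the series" means these compounds.

Three amides built on one shared core have been measured in an assay on C3H 10T1/2 cells for inhibition of Sonic hedgehog protein (Mus musculus), read by a luciferase reporter; a higher number here means a weaker inhibitor, a lower number a stronger inhibitor. Compound 1 `Cc1nc(C(F)(F)F)ccc1C(=O)Nc1ccc(Cl)c(-c2nc3ccccc3[nH]2)c1` gives 12 nM. Compound 2 `Cc1nc(C(F)(F)F)ccc1C(=O)Nc1ccc(Cl)c(-c2nc3c(n2C)CCCC3)c1` gives 150 nM, and compound 3 `Cc1nc(C(F)(F)F)ccc1C(=O)Nc1ccc(Cl)c(-n2cc3ccccc3n2)c1` gives 80 nM. Compound 3 therefore stands second highest of the three numbers: the step of a 6.7-fold higher number from compound 1 to compound 3 (0.82 log units; beyond the scatter) is beyond the scatter, whereas the step of a 1.9-fold lower number from compound 2 to compound 3 (0.27 log units; within the scatter) lies within it. Compound 4 `Cc1nc(C(F)(F)F)ccc1C(=O)Nc1ccc(Cl)c(-n2cccn2)c1` differs from compound 3 in one place: 1H-pyrazol-1-yl in place of 2H-indazol-2-yl on an aromatic carbon. Going by the values given here, no measured step removes a fused six-membered aromatic ring in this way, so none bears on it directly; the nearest comparisons are a 6.7-fold higher number from compound 1 to compound 3 (0.82 log units; beyond the scatter) and a 13-fold higher number from compound 1 to compound 2 (1.10 log units; beyond the scatter), both showing that reshaping this group moves the number, and in both cases upward. A modest step upward is therefore expected for compound 4, a 2.5-fold higher number from compound 3 to compound 4 (0.40 log units; beyond the scatter), with a real chance that it ends up within the scatter. In this assay compound 4 is estimated at 200 nM, with a range from 60 nM to 700 nM.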

Compound 4, half-maximal inhibitory concentration: 450 nM
Estimate against measurement, compound 4: 2.3-fold (0.35 log units) below, and the stated range covers the measured number.
By their numbers in this assay, from the lowest: compound 1; then compounds 3 and 2 (each within the scatter of the next); then compound 4.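

In this assay the step of a 5.6-fold higher number from compound 3 to compound 4 (0.75 log units; beyond the scatter) shows that the fused six-membered aromatic ring matters at this position, since removing it from 2H-indazol-2-yl to leave 1H-pyrazol-1-yl costs clearly more than the scatter. The single ring also falls short of both other groups, with a 3.0-fold higher number from compound 2 to compound 4 (0.48 log units; beyond the scatter) and a 38-fold higher number from compound 1 to compound 4 (1.57 log units; beyond the scatter) leaving compound 4 the weakest inhibitor of the four. Heavy-atom count alone does not set the order, however: compound 1, with a group of 9 heavy atoms, has a lower number than compound 2, with a larger group.

From the compounds shown here alone, whether a methyl group or an amine on the 1H-pyrazol-1-yl ring would win back any of this loss stays open. Nothing available here accounts for the loss.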